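Swapping Bromo for Trifluoromethyl on a Thiourea Aryl

A few compounds are considered here, and "the series" means these few. Any claim that something is new, unique, unknown or untested is made for them only; others in the source may bear on it.

The three measured compounds share one core and are tested in a functional assay on HeLa cells (Homo sapiens) for antiproliferative activity, with a stated time of 24 h; on this read-out lower numbers stand for stronger inhibition and higher numbers for weaker inhibition. Compound 1 `NC(=O)c1c(NC(=O)c2ccccc2Cl)sc2c1CCN(C(=S)Nc1ccccc1C(F)(F)F)C2` gives 26700 nM, and compound 2 `NC(=O)c1c(NC(=O)c2ccccc2Br)sc2c1CCN(C(=S)Nc1ccccc1C(F)(F)F)C2` gives 39600 nM; the change a 1.5-fold higher number from compound 1 to compound 2 (0.17 log units; within the scatter) stays within scatter. Compound 3 `Cc1ccccc1C(=O)Nc1sc2c(c1C(N)=O)CCN(C(=S)Nc1ccccc1Br)C2` reaches only the limit > 50000 nM in this assay, so no number is known for it, and it is the only one of the three that sits at the limit of > 50000 nM in this assay, at which 1 of the 3 values shown sits.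

Compound 4 `Cc1ccccc1C(=O)Nc1sc2c(c1C(N)=O)CCN(C(=S)Nc1ccccc1C(F)(F)F)C2` differs from compound 3 by trifluoromethyl in place of bromo on an aromatic carbon, on an aromatic carbon of a six-membered aromatic ring of carbon only, ortho to a large group. Among the compounds with values here, no measured step changes this position directly; the only measured step, from compound 1 to compound 2, concerns the other aryl ring and stays within scatter. Compounds 1 and 2 carry the trifluoromethyl group that enters compound 4 and each give a number in this assay, while compound 3 with bromo gives none. The step of an at least 1.1-fold lower number from compound 3 to compound 4 (0.04 log units; that floor lies within the scatter) is therefore expected to bring compound 4 to a measurable value, though this remains uncertain. Compound 4 is estimated at 45000 nM, with a range from 20000 nM to 100000 nM.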

Compound 4, half-maximal inhibitory concentration: > 50000 nM
Compound 4: only a limit was reported; the forecaster's own chance of this, stated with the estimate: 45%; middle value at least 1.1-fold (0.04 log units) away from the limit.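

In this assay compound 4 gives > 50000 nM, which is a limit of the assay and not a number. Trifluoromethyl in place of bromo on this aromatic carbon therefore does not by itself yield a measurable value, and the step between the two compounds cannot be read, as both stop at the same limit: the limit of > 50000 nM in this assay, at which 2 of the 4 values shown sit. On the other aryl ring, methyl in place of bromo gives an at least 1.2-fold higher number from compound 2 to compound 4 (0.10 log units; that floor lies within the scatter), and methyl in place of chloro gives an at least 1.8-fold higher number from compound 1 to compound 4 (0.27 log units; that floor lies within the scatter), so these floors alone do not establish a real loss from either swap.

As far as these compounds go, it remains open whether an amine or a carboxylic acid at this position would bring the methyl-bearing series to a measurable value. Also open, from the compounds shown here alone, is whether bromo on the thiourea aryl would give a number when chloro or bromo sits on the other ring.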